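A few compounds are considered here, and "the series" means these few. Any claim that something is new, unique, unknown or untested is made for them only; others in the source may bear on it.

Compound 1 `Cc1c(C)c2c(c(C)c1O)CCC(C)(C(=O)NC1CC(C)(C)N([O])C1(C)C)O2` gives 58000 nM in a functional assay on RPMI-8226 cells (Homo sapiens) for cytotoxicity, read by MTT assay, with a stated time of 72 h; a lower number here means a stronger inhibitor, a higher number a weaker inhibitor.
Compound 2 `Cc1c(C)c2c(c(C)c1OC(=O)CCC(=O)NC1CC(C)(C)N([O])C(C)(C)C1)CC[C@@](C)(CCC[C@H](C)CCC[C@H](C)CCCC(C)C)O2` gives > 300000 nM in this assay.
Compound 3 `Cc1c(C)c2c(c(C)c1O)CCC(C)(C(=O)NCC1CC(C)(C)N([O])C1(C)C)O2` gives 70000 nM in this assay.

Compound 1 and compound 3 both carry a nitroxide ring on an amide, and their two values in this assay lie within the usual scatter of each other. Compound 2 stands apart: for compound 2 this assay reports only a limit, > 300000 nM, not a number. This is the limit of > 300000 nM in this assay, at which 1 of the 3 values shown sits, so compound 2 sits at the edge of what the assay can tell and is the weakest inhibitor among the three measured compounds.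

Compound 4 `Cc1c(C)c2c(c(C)c1OC(=O)CCC(=O)NC1CC(C)(C)N([O])C1(C)C)CC[C@@](C)(CCC[C@H](C)CCC[C@H](C)CCCC(C)C)O2` is not yet measured. It keeps the whole of compound 2 except for one change on the amide-type nitrogen: a group of 10 heavy atoms (8 carbon, 1 nitrogen, 1 oxygen; one five-membered non-aromatic ring with 1 hetero atom) in place of a group of 11 heavy atoms (9 carbon, 1 nitrogen, 1 oxygen; one six-membered non-aromatic ring with 1 hetero atom), on an amide-type nitrogen. Within the data shown here, the two nitroxide rings differ by a single ring atom, a change of the same kind that separates the ring sizes within the measured set, where no step between measured compounds is available to size it.

With compound 2 already at the limit, the step from compound 2 to compound 4 in this assay is expected to be none beyond the scatter, a number no higher from compound 2 to compound 4 (the limit leaves the size open). Compound 4 is therefore expected to give about 300000 nM, within a range of 100000 nM to 1000000 nM, and most likely again only a limit.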

Compound 4, half-maximal inhibitory concentration: 55000 nM
Compound 4: middle estimate off by 5.5-fold (0.74 log units), on the high side; the measured number lies below the stated range.
By their numbers in this assay, from the lowest: compounds 4, 1 and 3 (each within the scatter of the next). At a limit, above all of these: compound 2.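

In this assay, the group on the amide-type nitrogen proves to matter: putting the group with one five-membered non-aromatic ring in place of the group with one six-membered non-aromatic ring gives an at least 5.4-fold lower number from compound 2 to compound 4 (0.73 log units; beyond the scatter). The earlier compounds shown here offered no step at all, whereas this pair shows that a change in ring size at this one place, with the rest of the molecule kept, can turn a limit into a measured number. Only the smallest possible size of this step can be stated, and the true size stays unknown because the value for compound 2 is a limit, not a number: the limit of > 300000 nM in this assay, at which 1 of the 4 values shown sits.

The compounds shown leave open whether the same ring swap has a comparable effect on a different core, or whether a seven-membered ring or an open chain on this nitrogen would lower the number further. They also leave open whether the oxygen on the ring nitrogen takes part in the change, which a matching ring carrying a plain amine in place of the nitroxide could test.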